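The compounds below may be only part of what the source reports. "The series", "measured", "known", "first", "only" and "open" are said of these compounds alone.

Measured so far in a functional assay on HT-29 cells (Homo sapiens) for cytotoxicity, read by MTT assay, with a stated time of 48 h; a lower number here means a stronger inhibitor, a higher number a weaker inhibitor:

Compound 1 `COC(=O)/C=C/c1ccc2c(c1)C(=O)C(=O)N2Cc1ccc(C)cc1`: 30 nM
Compound 2 `CC(C)(C)OC(=O)/C=C/c1ccc2c(c1)C(=O)C(=O)N2Cc1ccc(Br)cc1`: 730 nM
Compound 3 `COC(=O)/C=C/c1cccc2c1N(Cc1ccc(OC)cc1)C(=O)C2=O`: > 10000 nM, which is a limit of the assay rather than a number (the limit of > 10000 nM in this assay, at which 1 of the 3 values shown sits).

All three compounds carry the same core with a benzyl group on the nitrogen and an unsaturated ester on the aromatic ring. Compound 1 has the lowest of the two numbers recorded; compound 2 sits higher, and the gap between them is beyond the usual scatter of this assay. Compound 3 reaches only the limit and contributes no number to compare.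

Compound 4 `COC(=O)/C=C/c1ccc2c(c1)C(=O)C(=O)N2Cc1ccccc1` has not yet been measured. It differs from compound 1 in a single place: hydrogen in place of methyl on an aromatic carbon. Going by the values given here, no measured pair isolates this change, so its effect must be judged from the spread of the values at hand. A change this small, a single carbon removed from the edge of the benzyl group, is expected to move the number only modestly, most likely upward but not far outside the scatter; the expected step is a 2.3-fold higher number from compound 1 to compound 4 (0.37 log units; beyond the scatter). Compound 4 is therefore estimated at 70 nM, within a range from 20 nM to 300 nM.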

Compound 4, half-maximal inhibitory concentration: 70 nM
For compound 4 middle estimate and measured number coincide at the digits printed; the range from low to high includes it.
By their numbers in this assay, from the lowest: compound 1; then compound 4; then compound 2. At a limit, above all of these: compound 3.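

In this assay, taking the methyl off the 4-methylbenzyl group gives a 2.3-fold higher number from compound 1 to compound 4 (0.37 log units; beyond the scatter), and this is the first pair shown that differs in only one place, so the change can be read on its own. The step is modest but beyond the usual scatter, which means that this methyl contributes measurably to the lower number, while the plain benzyl group of compound 4 still gives 70 nM and the methyl is therefore not essential for strong activity in this series. Nothing measured here gives a property of the methyl group that would account for the step.

On these data alone, it remains open whether other groups in this place, such as an amine, a carboxylic acid or a longer chain like ethyl, would lower the number further or raise it sharply. Compound 2 differs from compound 1 in both the ester and the group on the benzyl ring, so the compounds shown do not separate the effect of the bromine from that of the tert-butyl ester.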